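Arylamide swap on the shared core: compound 1 to compound 4

A few compounds are considered here, and "the series" means these few. Any claim that something is new, unique, unknown or untested is made for them only; others in the source may bear on it.

Compound 1 `O=C(CSc1cccc(O)c1)Nc1ccc2nc(NC(=O)c3cc(Cl)cc(Cl)c3)sc2c1` is one of two compounds on the shared core that return a number in a functional assay on U2OS cells (Homo sapiens) for antiproliferative activity, read by MTT assay, with a stated time of 72 h; a higher number here means a weaker inhibitor, a lower number a stronger inhibitor. In this assay compound 1 gives 1530 nM, the higher of the two numbers. Compound 3 `Cc1ccc(SCC(=O)Nc2ccc3nc(NC(=O)c4ccc(C(F)(F)F)cc4)sc3c2)c(C)c1`, which carries a trifluoromethyl-bearing ring on the carbonyl carbon and a dimethylphenyl thioether, gives 1000 nM in this assay; the gap to compound 1 lies within the scatter, so the two stand level. Compound 2 `O=C(Cc1nnc(NC(=O)c2ccc(Cl)cc2)s1)N/N=C/c1ccc(O)cc1` is built on a different core. In this assay compound 2 reaches only a limit, > 100000 nM (the limit of > 100000 nM in this assay, at which 1 of the 3 values shown sits), and no number is reported for it. Among the measured compounds shown here, no two measured compounds differ in a single place, so no measured step is at hand.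

Compound 4 `Cc1ccc(C(=O)Nc2nc3ccc(NC(=O)CSc4cccc(O)c4)cc3s2)cc1` keeps the hydroxyphenyl thioether and the shared core of compound 1 and differs only at the arylamide: 4-methylphenyl in place of 3,5-dichlorophenyl on a carbonyl carbon. The step from compound 1 to compound 3 shows that changing the substituents on this ring, together with the thioether, leaves the number within the scatter. For compound 4 the step of a 1.4-fold higher number from compound 1 to compound 4 (0.16 log units; within the scatter) is therefore expected to stay within the scatter, or to rise slightly. Compound 4 is expected to give 2200 nM, in the range 700 nM to 7000 nM.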

Compound 4, half-maximal inhibitory concentration: 12400 nM
Compound 4: the middle estimate sits 5.6-fold (0.75 log units) below what was measured; the measured number lies above the stated range.
By their numbers in this assay, from the lowest: compounds 3 and 1 (each within the scatter of the next); then compound 4. At a limit, above all of these: compound 2.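

In this assay, 4-methylphenyl in place of 3,5-dichlorophenyl on a carbonyl carbon gives an 8.1-fold higher number from compound 1 to compound 4 (0.91 log units; beyond the scatter), with the hydroxyphenyl thioether and the shared core held fixed. Among the compounds shown here, this is the first step read at a single place, and it shows that the aryl group at this position can by itself move the number beyond the scatter, which the earlier compounds, none of them a single-place pair, could not show. Both groups are a six-membered aromatic ring of carbon only, neither carries a hydrogen-bond donor or acceptor, and neither has a net charge, so the difference lies in the substituents on that ring.

The swap takes away the chlorine atoms and brings in a methyl in one move, so the compounds shown do not separate the two parts of the change, and a plain phenyl on the same carbonyl carbon would be the group to divide them. Nothing measured here accounts for the size of this step.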